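This account rests on a few compounds, and the source may have more. Where it says the series, first, only, none or still open, it means among the compounds named here.

Measured so far in a functional assay on SK-MEL-28 cells (Homo sapiens) for inhibition, read by MTT assay, with a stated time of 72 h; a higher number here means a weaker inhibitor of growth, a lower number a stronger inhibitor of growth:
compound 1 `Clc1ccc(Sc2c(-c3ccc(Br)cc3)[nH]c3ccccc23)cc1` gives 26000 nM
compound 2 `O=C(COc1ccc(Cl)cc1)Nc1c(-c2ccccc2)[nH]c2ccccc12` gives 48000 nM
compound 3 `CCN(CC)C(=S)Sc1c(-c2ccccc2)[nH]c2ccc(Br)cc12` gives 28000 nM

All three numbers sit in a narrow band. Compound 3 stands second highest of the three; compound 1 is the nearest to it and compound 2 the furthest, and both gaps lie within the usual scatter of this assay, so no order among the three can be read from these figures.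

Compound 4 `CCN(CC)C(=S)Sc1c(-c2ccc(Br)cc2)[nH]c2ccc(Br)cc12` has not yet been measured. Set against compound 3, the change is bromo in place of hydrogen on an aromatic carbon. Cut one bond further out, the same change reads phenyl to 4-bromophenyl; compound 1 also carries a 4-bromophenyl group and sits in the same band, though it is not a single-change partner of compound 3 and no step between that pair is computed. Nothing in the set points to a large effect of this change. The expected step from compound 3 to compound 4 in this assay is a 1.1-fold lower number from compound 3 to compound 4 (0.05 log units; within the scatter), not beyond the scatter in either direction. Compound 4 is accordingly estimated at 25000 nM in this assay, with a range from 12000 nM to 52000 nM.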

Compound 4, concentration for 50% growth inhibition: 29000 nM
Compound 4: the middle estimate sits 1.2-fold (0.06 log units) below what was measured, within the range that was stated.
By their numbers in this assay, from the lowest: compounds 1, 3, 4 and 2 (each within the scatter of the next).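

In this assay, bromo in place of hydrogen on an aromatic carbon, para to a large group, gives a 1.0-fold higher number from compound 3 to compound 4 (0.02 log units; within the scatter). Among these compounds, this is the first single-change pair, which the earlier compounds could not provide, and it shows that phenyl to 4-bromophenyl at this position leaves the number within the scatter when the bromo on the shared core is present in both compounds. No measurement at hand speaks to the reason for this outcome.

Going by these compounds, whether a different group at this same place, such as an amine, a carboxylic acid or a longer chain, would give a step beyond the scatter remains open, as bromo is the only replacement for hydrogen seen here. Also open, on these data alone, is whether phenyl to 4-bromophenyl gives a similar step on a compound without the bromo on the shared core or with another sulfur-linked side group, as this single pair does not cover those cases.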